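Removing the chloro group: from compound 2 to compound 3

The compounds below may be only part of what the source reports. "The series", "measured", "known", "first", "only" and "open" are said of these compounds alone.

Compound 2 `COc1ccc(OC)c(/C=C/C(=O)N/N=C/c2ccc(Cl)cc2)c1` gives 3050 nM in a functional assay on HCT-116 cells (Homo sapiens) for antiproliferative activity, read by sulforhodamine B assay, with a stated time of 48 h (a higher number here means a weaker inhibitor of growth, a lower number a stronger inhibitor of growth), the lowest of the two numbers in hand. Compound 1 `COc1ccc(OC)c(/C=C/c2nnc(Nc3ccc(Cl)cc3)o2)c1` gives 13100 nM in this assay; the gap between compound 2 and compound 1 lies beyond the usual scatter, but the two structures differ in more than one place, so no single step can be read from that pair. Compound 3 `COc1ccc(OC)c(/C=C/C(=O)N/N=C/c2ccccc2)c1` has not yet been measured in this assay. It differs from compound 2 by hydrogen in place of chloro on an aromatic carbon. Among the compounds with values here, with no step between measured compounds to lean on, the size of this change is uncertain; a small rise in the number, near the edge of the scatter, is the working expectation. Compound 3 is estimated at 5000 nM in this assay, with a range from 2000 nM to 15000 nM. This estimate means a step of a 1.6-fold higher number from compound 2 to compound 3 (0.21 log units; within the scatter) in this assay, expected as a modest weakening rather than a firm change.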

Compound 3, concentration for total growth inhibition: 10200 nM
For compound 3 the middle estimate is 2.0-fold (0.31 log units) below the measured one; measured number inside the range.
By their numbers in this assay, from the lowest: compound 2; then compounds 3 and 1 (each within the scatter of the next).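

In this assay the series now has its first step at a single place: going from 4-chlorophenyl to phenyl, with hydrogen in place of chloro on an aromatic carbon, gives a 3.3-fold higher number from compound 2 to compound 3 (0.52 log units; beyond the scatter). This position, para to a large group, is therefore not silent in this pair: the step lies beyond the usual scatter, and the lower number belongs to the chlorinated member. Nothing in hand accounts for the size of this step.

As far as these compounds go, what remains open is whether the same exchange would give a step of similar size on the core of compound 1. Also open, from the compounds shown here alone, is how fluoro, bromo, a methyl group or an amine at this aromatic carbon would stand against chloro and hydrogen in this assay.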